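The source may hold more compounds than are shown below. What is called first, only, known or untested is meant among the compounds shown, and "the series" means these compounds.

Measured in an ADME assay on MT4 cells (Homo sapiens) for cytotoxicity, read by MTT assay, with a stated time of 4 days; on this read-out higher numbers stand for lower toxicity in this test and lower numbers for higher toxicity in this test:
- Compound 1 `CCN(C)c1nc(Cc2c(F)cccc2F)c(C)c(=O)[nH]1`: > 85000 nM, a limit
- Compound 2 `Cc1c(Cc2c(F)cccc2F)nc(N2CCCCC2)[nH]c1=O`: > 78000 nM, a limit

Compound 2 has no exact number in this assay. Going by the values given here, its only reading is the limit > 78000 nM.

Compound 3 `Cc1c(Cc2c(F)cccc2F)nc(N2CCC(C)CC2)[nH]c1=O` follows from compound 2 by placing methyl in place of hydrogen on a saturated ring carbon, which turns piperidin-1-yl into 4-methylpiperidin-1-yl (methyl in place of hydrogen on a saturated ring carbon).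

Among the compounds with values here, only one measured step bears on this change, a step that the two limits leave unreadable from compound 1 to compound 2, and its size cannot be read. It gives no sign that changes to this group move the read-out, but it cannot rule that out. No shift beyond the scatter is therefore expected, and the estimated step is an at least 1.0-fold lower number from compound 2 to compound 3 (0.01 log units; that floor lies within the scatter). Compound 3 is expected near 75000 nM, with an estimated range of 30000 nM to 100000 nM, and it will probably be reported as a limit too.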

Compound 3, half-maximal cytotoxic concentration: > 75000 nM
Compound 3 ended at the assay's limit; the forecaster's own chance of this, stated with the estimate: 80%; the middle value lies on the limit itself.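

In this assay compound 3 gives > 75000 nM, a limit. Compound 1 and compound 2 are also limits, so the steps among these three compounds cannot be read. The compounds shown leave open whether changing the amino group on the shared core alters cytotoxicity at all.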